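Trading 1-hydroxy-1-methylethyl for 3-fluoropyridin-2-yl: expected plasma binding

The source may report more compounds than this note shows. Statements on the series, on what has been measured and on what is new or still open speak of the compounds shown alone.

Measured so far (an ADME assay on a cell-free system (plasma, Rattus norvegicus) for protein binding)
- compound 1 (`Cc1ccc(-c2cc(C(=O)N[C@H](C)c3ccc(C(F)(F)F)[n+]([O-])c3)cc(C(C)(C)O)c2)nc1`) gives 62.4% here
- compound 2 (`Cc1ccc(-c2cc(C(=O)N[C@H](C)c3ccc(F)cn3)cc(C(C)(C)O)c2)nc1`) gives 82% here
- compound 3 (`Cc1ccc(-c2cc(C(=O)N[C@H](C)c3ccc(C(F)(F)F)[n+]([O-])c3)cc(C(C)(C)O)c2)cc1`) gives 95.4% here

Among these three, compound 1 (62.4%) has the highest unbound fraction, meaning the largest share of it stays free. Compound 4 (`Cc1ccc(-c2cc(C(=O)N[C@H](C)c3ccc(C(F)(F)F)[n+]([O-])c3)cc(-c3ncccc3F)c2)nc1`) keeps the rest of compound 1 but carries 3-fluoropyridin-2-yl in place of 1-hydroxy-1-methylethyl on an aromatic carbon.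

Within the data shown here, no measured step touches that place, so the evidence is indirect. Two changes elsewhere show how far this read-out can move. Exchanging the group on the saturated chain carbon gives a modest shift (a 2.1-fold lower unbound fraction from compound 1 to compound 2 (0.32 log units; beyond the scatter)). Putting 4-methylphenyl in place of 5-methylpyridin-2-yl gives a larger one (an 8.2-fold lower unbound fraction from compound 1 to compound 3 (0.91 log units; beyond the scatter)). Both lie beyond the scatter and both point the same way, though two steps make a thin basis.

In this assay a step towards less free compound is therefore expected, with a size between those two (a 3.1-fold lower unbound fraction from compound 1 to compound 4 (0.50 log units; beyond the scatter)). For compound 4 the estimated value is 88% (expected range 72% to 96%).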

Compound 4, plasma protein binding: 95.2%
Beside the measured number, compound 4's estimate is 2.5-fold (0.40 log units) (unbound fraction) above it, within the range that was stated.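

In this assay, the first change shown at this place, an aromatic carbon meta to a 5-methylpyridin-2-yl group, gives a 7.8-fold lower unbound fraction from compound 1 to compound 4 (0.89 log units; beyond the scatter), so this position can also move plasma binding beyond the scatter. That step is close in size to an 8.2-fold lower unbound fraction from compound 1 to compound 3 (0.91 log units; beyond the scatter) and larger than a 2.1-fold lower unbound fraction from compound 1 to compound 2 (0.32 log units; beyond the scatter), which means that a change here can count for as much as the largest step seen so far from compound 1. The swap removes an open-chain group carrying a hydrogen-bond donor and brings in a larger aromatic ring with a fluorine and no such donor, and no measurement here explains the shift or separates these differences.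

As far as these compounds go, it stays open whether the ring itself matters or its fluorine, which plain pyridin-2-yl at the same place would help to separate. Also open, from the compounds shown here alone, is how the binding would respond to quite different groups here, such as a carboxylic acid or an amine, and whether the free share of compound 1 could be raised further by such a change.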